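A few compounds are considered here, and "the series" means these few. Any claim that something is new, unique, unknown or untested is made for them only; others in the source may bear on it.

Compound 2, `C#CCOCN1c2ccccc2C(=O)N(Cc2ccccc2)S1(=O)=O`, is one of two closely related compounds examined in a functional assay on HeLa cells (Homo sapiens) for cytotoxicity; on this read-out higher numbers stand for lower toxicity in this test and lower numbers for higher toxicity in this test. In this assay compound 2 reaches only the limit of the test, > 50 ug/mL. Its companion, compound 1, `O=C1c2ccccc2N(COCc2ccccc2)S(=O)(=O)N1Cc1ccccc1`, likewise gives only a limit in this assay, namely > 50 ug/mL. the limit of > 50 ug/mL in this assay, at which 2 of the 2 values shown sit, sums this up: both numbers are limits rather than measured values, so the change a step that the two limits leave unreadable from compound 1 to compound 2 cannot be sized. Compound 3, `O=C(OCCOCN1c2ccccc2C(=O)N(Cc2ccccc2)S1(=O)=O)c1ccccc1`, is not yet measured; it differs from compound 2 by (benzoyloxy)methyl in place of ethynyl on a saturated chain carbon bound to an oxygen on a saturated carbon. Going by the values given here, the only comparable step, from compound 1 to compound 2, is unreadable, so no measured step bears on this new change. Compound 3 is therefore expected to stay where its two relatives sit, with an estimated step of a number no higher from compound 2 to compound 3 (the limit leaves the size open) that does not exceed the scatter. For compound 3 the estimate in this assay is 50 ug/mL, within a range from 30 ug/mL to 100 ug/mL, most probably reported again only as a limit.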

Compound 3, half-maximal cytotoxic concentration: 24 ug/mL
For compound 3 the middle estimate is 2.1-fold (0.32 log units) above the measured one; the whole stated range lies above it.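

Going by these compounds alone, the (benzoyloxy)methyl group gives the first readable change at this place, a saturated chain carbon bound to an oxygen on a saturated carbon: in this assay there is an at least 2.0-fold lower number from compound 2 to compound 3 (0.31 log units; beyond the scatter), and the comparison with the phenyl compound shows an at least 2.0-fold lower number from compound 1 to compound 3 (0.31 log units; beyond the scatter). Lower numbers here stand for higher toxicity, so a change at this place can make a compound more toxic to these cells, which the two earlier compounds could not reveal. The true size of both steps stays open, as each starts from a limit and not from a measured value: the limit of > 50 ug/mL in this assay, at which 2 of the 3 values shown sit.

The compounds shown do not separate the contribution of the benzoyloxy part from that of the longer chain that carries it. A 2-hydroxyethyl group or a plain butyl chain at this place would bear on that question.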